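Nitro in Place of Methoxy: What to Expect for Compound 4

A few compounds are considered here, and "the series" means these few. Any claim that something is new, unique, unknown or untested is made for them only; others in the source may bear on it.

Compound 1 `COc1ccc(NC(=O)Nc2ccc(C(=O)NO)cc2)cc1` and compound 2 `O=C(Nc1ccc(C(=O)NO)cc1)Nc1ccc([N+](=O)[O-])cc1` share a core and differ by nitro in place of methoxy on an aromatic carbon. In a functional assay on Jurkat cells (Homo sapiens) for cytotoxicity, read by MTT assay, with a stated time of 72 h (a lower number here means a stronger inhibitor, a higher number a weaker inhibitor), compound 1 gives 8030 nM, while compound 2 gives 12700 nM, so that a 1.6-fold higher number from compound 1 to compound 2 (0.20 log units; within the scatter). Compound 3 `COc1ccc(NC(=O)Nc2ccc(CCC(=O)NO)cc2)cc1` differs from compound 1 by 2-(hydroxycarbamoyl)ethyl in place of hydroxycarbamoyl on an aromatic carbon; in this assay compound 3 gives 2800 nM, and the step of a 2.9-fold lower number from compound 1 to compound 3 (0.46 log units; beyond the scatter). Compound 4 `O=C(CCc1ccc(NC(=O)Nc2ccc([N+](=O)[O-])cc2)cc1)NO` has not yet been measured. It differs from compound 3 by nitro in place of methoxy on an aromatic carbon, the same change as that from compound 1 to compound 2, at a place described in identical words. That earlier step, a 1.6-fold higher number from compound 1 to compound 2 (0.20 log units; within the scatter), stayed within the scatter. On that basis a comparable step is expected for compound 4: a 1.6-fold higher number from compound 3 to compound 4 (0.21 log units; within the scatter). Compound 4 is therefore estimated at 4500 nM, expected to fall between 2000 nM and 10000 nM.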

Compound 4, half-maximal inhibitory concentration: 810 nM
For compound 4 the middle estimate is 5.6-fold (0.74 log units) above the measured one; measured number outside the range, below it.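

In this assay, nitro in place of methoxy gave a 3.5-fold lower number from compound 3 to compound 4 (0.54 log units; beyond the scatter), so this change did not carry over from one core to the other in size or direction: the same change on two cores in this assay, a 1.6-fold higher number (0.20 log units; within the scatter) from compound 1 to compound 2 and a 3.5-fold lower number (0.54 log units; beyond the scatter) from compound 3 to compound 4, 5.5-fold (0.74 log units) apart, beyond the scatter of two such steps
2-(hydroxycarbamoyl)ethyl in place of hydroxycarbamoyl gave a 16-fold lower number from compound 2 to compound 4 (1.20 log units; beyond the scatter), the same direction as on the methoxy core but a different size: the same change on two cores in this assay, a 2.9-fold lower number (0.46 log units; beyond the scatter) from compound 1 to compound 3 and a 16-fold lower number (1.20 log units; beyond the scatter) from compound 2 to compound 4, 5.5-fold (0.74 log units) apart, beyond the scatter of two such steps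
These four compounds show that the two changes do not simply add in this series, but not why, nor whether this extends beyond these compounds.

As far as these compounds go, whether an amine or a chlorine atom in place of methoxy would also depend on the core remains open. So does the outcome with a longer chain carrying the hydroxycarbamoyl group.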